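Swapping the methoxycarbonyl group of compound 1

The source may report more compounds than this note shows. Statements on the series, on what has been measured and on what is new or still open speak of the compounds shown alone.

Compound 1 `COC(=O)Cn1c(=O)oc2c(C(=O)/C=C/c3ccc(O)cc3)cccc21`: 1.46
Compound 2 `COC(=O)Cn1c(=O)oc2c(C(=O)/C=C/c3cc(F)c(O)c(F)c3)cccc21`: 1.07

Of the two compounds measured in a physicochemical assay for lipophilicity, read by HPLC, using the shake flask method, measured as octanol-water partition, with a stated time of 24 h, at pH 7.4 (on this read-out lower numbers stand for lower lipophilicity and higher numbers for higher lipophilicity), compound 1 stands highest at 1.46. Compound 3 `CC(C)=CCn1c(=O)oc2c(C(=O)/C=C/c3ccc(O)cc3)cccc21` has not been measured yet. It differs from compound 1 in one place: 2-methylprop-1-en-1-yl in place of methoxycarbonyl on a saturated chain carbon bound to an aromatic nitrogen. In words, 2-methylprop-1-en-1-yl comes in place of methoxycarbonyl on a saturated chain carbon bound to an aromatic nitrogen.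

Among the measured compounds shown here, the only measured step is a number 0.39 log units lower from compound 1 to compound 2 (beyond the scatter). It is a change elsewhere in the molecule, 3,5-difluoro-4-hydroxyphenyl in place of 4-hydroxyphenyl, so it says little about this chain. The expectation therefore rests on the structural change itself: the oxygens of the leaving group go, and only carbon enters. The expected step in this assay is a number 1.44 log units higher from compound 1 to compound 3 (beyond the scatter), larger than the measured one. For compound 3 the estimate is 2.9, with an expected range of 2.2 to 3.6.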

Compound 3, distribution coefficient: 1.65
Compound 3: middle estimate off by 1.25 log units, on the high side, and the stated range ends above it.
By their numbers in this assay, from the lowest: compound 2; then compounds 1 and 3 (each within the scatter of the next).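

Read in this assay, the exchange at this position gives a number 0.19 log units higher from compound 1 to compound 3 (within the scatter) and so separates compound 1 from compound 3 by no more than repeat measurements would. On this one pair, then, a group of 2 carbon and 2 oxygen atoms can give way to one of 4 carbon atoms, with hydrogen-bond acceptors going from 2 to 0, without a reading beyond the scatter. Nothing available accounts for this small a step.

On these data alone, whether other groups on the same saturated chain carbon would behave alike stays open, and an amine, a carboxylic acid or a longer chain there would test it. As far as these compounds go, it is also open whether 3,5-difluoro-4-hydroxyphenyl in place of 4-hydroxyphenyl would give a similar step when the 3-methylbut-2-en-1-yl chain is present.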